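Moving the chlorine on the amide aryl ring

The source may hold more compounds than are shown below. What is called first, only, known or untested is meant among the compounds shown, and "the series" means these compounds.

Compound 1 `O=C(Nc1c(C(O)(C(F)(F)F)C(F)(F)F)ccc2ccccc12)C1CCCC1`, 495 nM; compound 2 `O=C(Nc1c(C(O)(C(F)(F)F)C(F)(F)F)ccc2ccccc12)c1ccccc1Cl`, 2040 nM.

In an assay on LtK cells with ATP-sensitive inward rectifier potassium channel 11 (Homo sapiens) as the target (on this read-out higher numbers stand for an effect only at larger amounts of compound and lower numbers for an effect already at smaller amounts), compound 2 has the higher of the two numbers, the nearest being compound 1, reached by a 4.1-fold higher number from compound 1 to compound 2 (0.62 log units; beyond the scatter). Compound 3 `O=C(Nc1c(C(O)(C(F)(F)F)C(F)(F)F)ccc2ccccc12)c1cccc(Cl)c1` differs from compound 2 by 3-chlorophenyl in place of 2-chlorophenyl on a carbonyl carbon. Among the measured compounds shown here, no measured step moves a chlorine within the aryl ring, so the direction of this change cannot be read from the data; the only step known, cyclopentyl to 2-chlorophenyl, does not bear on it directly. Compound 3 is therefore expected to lie near compound 2, with a 1.4-fold lower number from compound 2 to compound 3 (0.13 log units; within the scatter) as the estimated step. The estimate for compound 3 is 1500 nM, within 400 nM to 6000 nM.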

Compound 3, half-maximal effective concentration: 98 nM
For compound 3 the middle estimate is 15-fold (1.18 log units) above the measured one; the whole stated range lies above it.
By their numbers in this assay, from the lowest: compound 3; then compound 1; then compound 2.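

In this assay the place of the chlorine on the aryl ring counts for much, since the two compounds hold the same atoms and yet show a 21-fold lower number from compound 2 to compound 3 (1.32 log units; beyond the scatter) in a step larger than the earlier swap of groups. An aryl amide is also not poorer than the cyclopentyl amide as such, given a 5.1-fold lower number from compound 1 to compound 3 (0.70 log units; beyond the scatter), while compound 2 goes the other way. Nothing at hand explains this gap. Left open is whether phenyl without chlorine, or a methoxy or nitrile in place of the chlorine in 3-chlorophenyl, would keep the low number of compound 3 .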